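Thiophenyl for pyridinyl: expected cytotoxicity of compound 3

A few compounds are considered here, and "the series" means these few. Any claim that something is new, unique, unknown or untested is made for them only; others in the source may bear on it.

Compound 1 `O=C(O)/C=C/c1ccc(NC(=O)C2(NC(=O)c3ccc4c(c3)nc(-c3ccoc3)n4C3CCCCC3)CCC2)cc1` and compound 2 `O=C(O)/C=C/c1ccc(NC(=O)C2(NC(=O)c3ccc4c(c3)nc(-c3ccccn3)n4C3CCCCC3)CCC2)cc1` share one core and differ only at the group on the five-membered ring of that core. In an ADME assay on Huh-7 cells (Homo sapiens) for cytotoxicity (on this read-out higher numbers stand for lower toxicity in this test and lower numbers for higher toxicity in this test), compound 1 gives > 10 uM, which is a limit of the assay and not a number. In this assay compound 2 gives > 10 uM, again a limit. The step that the two limits leave unreadable from compound 1 to compound 2 is therefore unreadable. Compound 2 thus stands at the limit of > 10 uM in this assay, at which 2 of the 2 values shown sit, the same position as every value shown.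

Compound 3 `O=C(O)/C=C/c1ccc(NC(=O)C2(NC(=O)c3ccc4c(c3)nc(-c3ccsc3)n4C3CCCCC3)CCC2)cc1` differs from compound 2 by thiophen-3-yl in place of pyridin-2-yl on an aromatic carbon. Within the data shown here, the only measured step bearing on this change is a step that the two limits leave unreadable from compound 1 to compound 2, whose size cannot be read, so nothing beyond the scatter is expected in this assay. Compound 3 is accordingly estimated at 20 uM, with a range from 8 uM to 50 uM. This expected step that the limit leaves unreadable from compound 2 to compound 3 amounts to no change beyond the scatter, most likely reported again as a limit.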

Compound 3, half-maximal toxic concentration: > 10 uM
Compound 3 gave a limit, no number; the forecaster's own chance of this, stated with the estimate: 80%; the middle value does not contradict the limit.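

In this assay compound 3 gives > 10 uM, a limit of the assay and not a number. No step among compound 1, compound 2 and compound 3 can therefore be read, and all three stand at one position: the limit of > 10 uM in this assay, at which 3 of the 3 values shown sit.

The compounds shown leave open whether furan-3-yl, pyridin-2-yl or thiophen-3-yl on the shared core makes any difference in this assay.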